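Swapping the aryl ring on a dienone side chain

The source may hold more compounds than are shown below. What is called first, only, known or untested is meant among the compounds shown, and "the series" means these compounds.

In a functional assay on LNCaP cells (Homo sapiens) for cytotoxicity, read by MTT assay, with a stated time of 72 h (on this read-out lower numbers stand for stronger inhibition and higher numbers for weaker inhibition), compound 2 `CC1=C(/C=C/C(=O)/C=C/c2ccc(F)cc2)C(C)(C)CCC1` gives 7300 nM, the highest of the two numbers shown, while compound 1 `CC1=C(/C=C/C(=O)/C=C/c2cccc(C(F)(F)F)c2)C(C)(C)CCC1` gives 2800 nM, a gap beyond the usual scatter. Compound 3 `CC1=C(/C=C/C(=O)/C=C/c2cccc(C)c2)C(C)(C)CCC1` has not yet been measured in this assay. It differs from compound 2 by 3-methylphenyl in place of 4-fluorophenyl on a double-bonded chain carbon bound to a double-bonded chain carbon. Going by the values given here, no measured pair shows a step of this kind, so the expectation is a 1.6-fold lower number from compound 2 to compound 3 (0.21 log units; within the scatter), a modest move toward a lower number that may not clear the scatter. Compound 3 is therefore estimated at 4500 nM, with a range from 1800 nM to 11000 nM.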

Compound 3, half-maximal inhibitory concentration: 17800 nM
The estimate for compound 3 lay 4.0-fold (0.60 log units) below the measured number, and the stated range ends below it.
By their numbers in this assay, from the lowest: compound 1; then compound 2; then compound 3.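

In this assay, 3-methylphenyl in place of 4-fluorophenyl on this chain carbon gives a 2.4-fold higher number from compound 2 to compound 3 (0.39 log units; beyond the scatter), so the choice of aryl ring moves the number beyond the scatter, and in the direction of weaker inhibition. Methyl in place of trifluoromethyl on an aromatic carbon gives a 6.4-fold higher number from compound 1 to compound 3 (0.80 log units; beyond the scatter), which shows that the group on that carbon alone also matters. Nothing measured here explains either step. The compounds shown leave open how an amine or a carboxylic acid on that aromatic carbon would read.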